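The source may hold more compounds than are shown below. What is called first, only, known or untested is meant among the compounds shown, and "the series" means these compounds.

Series notes. Compound 1 `CCCOC(=O)C1=C(C)NC(=S)NC1c1ccco1`, compound 2 `CC1=C(C(=O)OCC(C)C)C(c2ccco2)NC(=S)N1` and compound 3 `CC1=C(C(=O)OCc2ccccc2)C(c2ccco2)NC(=S)N1` share one core and differ only in the ester group. In an assay on membranes from CHO cells for displacement of a labelled ligand from adenosine receptor A1 (Homo sapiens), read by scintillation counting, with a stated time of 60 min, tested at 1 uM (a lower number here means less inhibition, a higher number more inhibition at the concentration tested (going by the name of the read-out)), compound 1 gives 1%, compound 2 gives 7% and compound 3 gives 32%. The step of a number 6 percentage points higher from compound 1 to compound 2 (within the scatter) lies inside the usual spread, whereas a number 31 percentage points higher from compound 1 to compound 3 (beyond the scatter) and a number 25 percentage points higher from compound 2 to compound 3 (beyond the scatter) lie outside it, so compound 3 stands highest of the three, with compound 2 nearest and compound 1 furthest.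

Compound 4 `CC1=C(C(=O)OCc2ccccc2)C(c2cccs2)NC(=S)N1` keeps the benzyl ester of compound 3 and changes the ring on the saturated ring carbon: thiophen-2-yl in place of furan-2-yl on a saturated ring carbon. Among the compounds with values here, none of the measured steps touches this position; all three vary the ester alkyl group, so none bears directly on the step from compound 3 to compound 4. The furan-2-yl group is the same in compounds 1, 2 and 3, and no comparison of one five-membered ring against another exists in the set. Within the data shown here, with no relevant step in hand, the working expectation is a step around zero, no change at the digits printed from compound 3 to compound 4 (within the scatter), within the scatter. Compound 4 is therefore estimated at 32% in this assay, with an expected range of 15% to 50%.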

Compound 4, a percentage reported as inhibition, at one concentration (the size of the read-out at that concentration, not a potency): 34%
Estimate against measurement, compound 4: 2 percentage points below, within the range that was stated.
By their numbers in this assay, from the lowest: compounds 1 and 2 (each within the scatter of the next); then compounds 3 and 4 (each within the scatter of the next).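

Within the data shown here, at the saturated ring carbon of the six-membered non-aromatic ring, the earlier compounds offered no comparison, since all three carry furan-2-yl and differ only in the ester group. In this assay, with the benzyl ester held fixed, thiophen-2-yl in place of furan-2-yl gives a number 2 percentage points higher from compound 3 to compound 4 (within the scatter), so this exchange of one five-membered aromatic ring for another, with sulfur replacing oxygen as the hetero atom and the same number of heavy atoms, does not separate the two compounds in this read-out at the concentration tested. The series thus has a ring exchange that stays inside the scatter, alongside an ester exchange, a number 25 percentage points higher from compound 2 to compound 3 (beyond the scatter), that is printed as beyond it, and nothing measured here gives a reason for the outcome of the ring exchange.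

From the compounds shown here alone, the thiophen-2-yl group appears only with the benzyl ester, so it remains open whether the same exchange would read alike with the propyl or isobutyl ester. Also open, going by these compounds, is how this ring carbon would respond to a group further from furan-2-yl, such as a phenyl ring, a pyridine ring or a saturated chain.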